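Replacing the Formyl Group of Compound 2

The source may hold more compounds than are shown below. What is called first, only, known or untested is meant among the compounds shown, and "the series" means these compounds.

Two measured compounds open the account. Compound 1 `CO[C@]1(C)/C=C/C(=O)/C(CO)=C\C[C@](C)(CCC=C(C)C)/C=C/[C@H]1OC(=O)C=C(C)C` in a functional assay on MCF7 cells (Homo sapiens) for antiproliferative activity, read by MTT assay, with a stated time of 48 h (on this read-out lower numbers stand for stronger inhibition and higher numbers for weaker inhibition), gives 14300 nM. Compound 2 `CC(C)=CCC[C@]1(C)/C=C/[C@@H](OC(=O)C=C(C)C)[C@](C)(O)/C=C/C(=O)/C(C=O)=C\C1` in this assay gives 12600 nM, and these two numbers lie within the usual scatter of each other, so neither compound can be set apart from the other on this read-out.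

Compound 3 `CC(C)=CCC[C@]1(C)/C=C/[C@@H](OC(=O)C=C(C)C)[C@](C)(O)/C=C/C(=O)/C(CN2CCN(C)CC2)=C\C1` has not yet been measured. It differs from compound 2 in one place: (4-methylpiperazin-1-yl)methyl in place of formyl on a double-bonded ring carbon. Going by the values given here, no step between measured compounds bears on this exchange, so any expectation rests on compound 2 alone. The formyl group leaves and a larger group with a six-membered ring enters on the same double-bonded ring carbon; nothing in the measured numbers says which way the result will move. The author expects the step from compound 2 to compound 3 to be modest, a 1.2-fold higher number from compound 2 to compound 3 (0.08 log units; within the scatter), without a clear direction beyond the scatter. For compound 3 the estimate in this assay is 15000 nM, with a range from 4000 nM to 50000 nM.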

Compound 3, half-maximal inhibitory concentration: 550 nM
Compound 3: the middle estimate sits 27-fold (1.44 log units) above what was measured; the measured number lies below the stated range.
By their numbers in this assay, from the lowest: compound 3; then compounds 2 and 1 (each within the scatter of the next).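

In this assay, the double-bonded ring carbon that carries formyl in compound 2 proves to be a place where a single change matters: (4-methylpiperazin-1-yl)methyl there gives a 23-fold lower number from compound 2 to compound 3 (1.36 log units; beyond the scatter). The two earlier numbers, which lay within the scatter of each other, gave no sign of this, and the step shows that this position accepts a much larger group with a six-membered ring without any loss on this read-out. Nothing shown accounts for the size of this step.

The compounds shown leave open whether the ring, its methyl group or simply an amine on this carbon carries the step, which a morpholin-4-ylmethyl or dimethylaminomethyl group at the same place would help to separate. They also leave open whether the same exchange would act alike on the core of compound 1, which bears a methoxy group.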